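Swapping a 2-Chlorophenyl Arm for 4-Methylphenyl

This account rests on a few compounds, and the source may have more. Where it says the series, first, only, none or still open, it means among the compounds named here.

Compound 1 `COc1ccc(-c2nnc(-n3[se]c4ccccc4c3=O)s2)cc1` gives 5930 nM in a functional assay on A549 cells (Homo sapiens) for antiproliferative activity, read by CCK-8 assay, with a stated time of 48 h; a higher number here means a weaker inhibitor, a lower number a stronger inhibitor. Compound 2 `O=c1c2ccccc2[se]n1-c1nnc(-c2ccc(F)cc2)s1` gives 21100 nM in this assay. Compound 3 `O=c1c2ccccc2[se]n1-c1nnc(-c2ccccc2Cl)s1` gives 10100 nM in this assay.

Compound 3 holds the second highest of these three numbers; it sits within the scatter of compound 1 and beyond the scatter of compound 2. Compound 4 `Cc1ccc(-c2nnc(-n3[se]c4ccccc4c3=O)s2)cc1` has not been measured; it differs from compound 3 by 4-methylphenyl in place of 2-chlorophenyl on an aromatic carbon. For the measured compounds named here, no measured step exchanges exactly these two groups. The two steps that do touch this arm, a 3.6-fold higher number from compound 1 to compound 2 (0.55 log units; beyond the scatter) and a 2.1-fold lower number from compound 2 to compound 3 (0.32 log units; beyond the scatter), were both modest and ran in opposite directions. The expected step of a 1.1-fold lower number from compound 3 to compound 4 (0.05 log units; within the scatter) in this assay is therefore small, within the scatter, with no clear direction. Compound 4 is estimated at 9000 nM, between 4000 nM and 25000 nM.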

Compound 4, half-maximal inhibitory concentration: 13400 nM
The estimate for compound 4 lay 1.5-fold (0.17 log units) below the measured number; measured number inside the range.
By their numbers in this assay, from the lowest: compounds 1, 3, 4 and 2 (each within the scatter of the next, the first and the last beyond it).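

In this assay, the 4-methylphenyl arm is not separable from the 2-chlorophenyl arm (a 1.3-fold higher number from compound 3 to compound 4 (0.12 log units; within the scatter)), so this change on the aromatic carbon of the five-membered ring has no clear effect. On the phenyl arm, methyl is also not separable from fluoro (a 1.6-fold lower number from compound 2 to compound 4 (0.20 log units; within the scatter)). Methyl is separable from methoxy, though only modestly (a 2.3-fold higher number from compound 1 to compound 4 (0.35 log units; beyond the scatter)), so among these three groups methoxy alone stands apart from both others.

From the compounds shown here alone, what an amine, a carboxylic acid or a longer chain on this arm would do remains open. Nothing available here explains these differences.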